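Nonyl ethers with an allyl cap: expected cytotoxicity

This account rests on a few compounds, and the source may have more. Where it says the series, first, only, none or still open, it means among the compounds named here.

Measured compounds:
compound 1 `CCCCCCCCCO[C@@H]1[C@@H](N)[C@@H](O[C@H]2[C@H](O)[C@@H](O)[C@H](N)C[C@@H]2N)O[C@H](CN)[C@H]1OCCCCCCCCC`, 48.6%
compound 2 `C=CCO[C@H]1O[C@H](CN)[C@@H](OCc2ccc3ccccc3c2)[C@H](OCc2ccc3ccccc3c2)[C@H]1N`, 28.3%
compound 3 `C=CCO[C@H]1O[C@H](CN)[C@@H](OCCCc2ccc3ccccc3c2)[C@H](OCCCc2ccc3ccccc3c2)[C@H]1N`, 7%

In a toxicity assay on the whole organism (J774 cells) for cytotoxicity, with Mus musculus as the target, read by MTT assay, with a stated time of 24 h, tested at 30 uM (on this read-out lower numbers stand for a stronger effect and higher numbers for a weaker effect at the one concentration tested), compound 1 gives 48.6%, the highest of the three numbers, so it is the compound with the weakest effect here. Compound 2 gives 28.3%, a number lying beyond the scatter below compound 1, and compound 3 gives 7%, lying even further below. Both of these carry an allyl group on the sugar where compound 1 carries its larger ring.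

Compound 4 `C=CCO[C@H]1O[C@H](CN)[C@@H](OCCCCCCCCC)[C@H](OCCCCCCCCC)[C@H]1N` has not yet been measured. Compared with compound 1, the change is allyl in place of 4,6-diamino-2,3-dihydroxycyclohexyl on an oxygen on a saturated carbon. The 4,6-diamino-2,3-dihydroxycyclohexyl leaves, allyl enters, and the two nonyl chains stay as they are.

Among the measured compounds shown here, with no measured pair that makes exactly this step, the direction can only be taken from the two allyl-capped compounds: compound 2 gives 28.3% and compound 3 gives 7%, both sitting well below the number of compound 1. A downward step is therefore expected, and beyond the scatter: the step from compound 1 to compound 4 is estimated at a number 22.6 percentage points lower from compound 1 to compound 4 (beyond the scatter). Compound 4 is expected to give about 26%, within a range from 8% to 48%.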

Compound 4, a percentage reported as activity, at one concentration (the size of the read-out at that concentration, not a potency): 6.6%
Compound 4: middle estimate off by 19.4 percentage points, on the high side, outside the stated range (below it).
By their numbers in this assay, from the lowest: compounds 4 and 3 (each within the scatter of the next); then compound 2; then compound 1.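

In this assay, putting allyl in place of 4,6-diamino-2,3-dihydroxycyclohexyl on an oxygen on a saturated carbon gives a number 42 percentage points lower from compound 1 to compound 4 (beyond the scatter) while the two nonyl chains stay as they are. Among the compounds shown here, this is the first direct reading of this position, since compound 2 and compound 3 differ from compound 1 in more than one place and cannot separate the effect of this exchange from that of the chains. No measurement shown here accounts for a step of this size.

Allyl is the only replacement for compound 1's group shown at this oxygen, so it remains open how a propyl chain or a 2-aminoethyl group would read there. From the compounds shown here alone, it also remains open whether the same exchange would give a similar step with hexyl chains in place of the two nonyl chains.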